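The source may hold more compounds than are shown below. What is called first, only, known or untested is meant among the compounds shown, and "the series" means these compounds.

Working notes on the series. In a functional assay on WRL68 cells (Homo sapiens) for cytotoxicity, read by MTT assay, with a stated time of 24 h (on this read-out lower numbers stand for stronger inhibition and higher numbers for weaker inhibition), compound 1 `COc1ccc(C2CC(=O)c3cc(OC)c(OC)c(OC)c32)c(OC)c1OC` gives 23 nM. Compound 2 `COc1cc(C2CC(=O)c3cc(OC)c(OC)c(OC)c32)cc(OC)c1OC` gives 12800 nM in this assay; on the two numbers at hand compound 2 stands highest, and its gap to compound 1 lies beyond the scatter. Among the compounds with values here, no single-change step between measured compounds exists, so nothing can yet be read from one change on the shared core. Compound 3 `COc1cc2c(cc1OC)C(c1cc(OC)c(OC)c(OC)c1)CC2=O` remains to be measured in this assay. It differs from compound 2 by hydrogen in place of methoxy on an aromatic carbon, the change sitting on an aromatic carbon of the fused ring, ortho to a fused ring and ortho to a methoxy group. Within the data shown here, with no comparable step measured, the step from compound 2 to compound 3 is expected to be none beyond the scatter, a 1.2-fold higher number from compound 2 to compound 3 (0.07 log units; within the scatter). Compound 3 is accordingly estimated at 15000 nM in this assay, with a range of 5000 nM to 50000 nM.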

Compound 3, half-maximal inhibitory concentration: 196000 nM
The estimate for compound 3 lay 13-fold (1.12 log units) below the measured number, and the stated range ends below it.
By their numbers in this assay, from the lowest: compound 1; then compound 2; then compound 3.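

Hydrogen in place of methoxy on this aromatic carbon, ortho to a fused ring and ortho to a methoxy group, is the first single change that can be read in the series: in this assay it gives a 15-fold higher number from compound 2 to compound 3 (1.19 log units; beyond the scatter). The position therefore bears on the read-out, and on this one pair the methoxy group goes with the lower number. Nothing at hand accounts for the size of this step.

As far as these compounds go, whether a hydroxyl, an amine or a fluorine atom on this carbon would keep the number near that of compound 2 remains open, so the pair does not tell whether methoxy itself matters or any group other than hydrogen would serve. Also open, from the compounds shown here alone, is whether the same change on compound 1 would give a step of similar size.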